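Series notes: from compound 2 to compound 3

This account rests on a few compounds, and the source may have more. Where it says the series, first, only, none or still open, it means among the compounds named here.

Measured so far in a functional assay on HeLa cells (Homo sapiens) for inhibition, read by MTT assay, with a stated time of 72 h; on this read-out higher numbers stand for weaker inhibition and lower numbers for stronger inhibition
- compound 1 (`COc1cc(NC(C)CCCNC(=O)Nc2cccc(F)c2)c2ncccc2c1`) gives 18000 nM
- compound 2 (`COc1cc(NC(C)CCCNC(=O)Nc2cccc(C(F)(F)F)c2)c2ncccc2c1`) gives 14000 nM

In this assay compound 2 at 14000 nM stands within the scatter of compound 1, so the two values cannot be ranked. Among the measured compounds shown here, the only measured step (a 1.3-fold lower number from compound 1 to compound 2 (0.11 log units; within the scatter)) is trifluoromethyl in place of fluoro on an aromatic carbon, and it stays within the scatter.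

The next compound is compound 3 (`COc1cc(NC(C)CCCNC(=O)NNC(=O)Nc2cccc(Cl)c2)c2ncccc2c1`). It carries ((3-chlorophenyl)carbamoyl)amino in place of 3-(trifluoromethyl)phenyl on an amide-type nitrogen. For the measured compounds named here, this is a larger change than the one measured, and no measured step covers it. The step from compound 1 therefore bears on it only loosely, and the data fix no direction.

Going by the values given here, with only that step as a guide, the expected step (a 1.1-fold higher number from compound 2 to compound 3 (0.03 log units; within the scatter)) is none beyond the scatter, though with wide uncertainty. For compound 3 the estimated value is 15000 nM with an expected range from 5000 nM to 40000 nM in this series.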

Compound 3, half-maximal inhibitory concentration: 44000 nM
Compound 3: the middle estimate sits 2.9-fold (0.47 log units) below what was measured; the measured number lies above the stated range.
By their numbers in this assay, from the lowest: compounds 2 and 1 (each within the scatter of the next); then compound 3.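

In this assay, among the compounds shown here, the amide-type nitrogen whose other neighbour is the carbonyl carbon gives the first step that lies beyond the scatter: ((3-chlorophenyl)carbamoyl)amino gives a 3.1-fold higher number from compound 2 to compound 3 (0.50 log units; beyond the scatter) and a 2.4-fold higher number from compound 1 to compound 3 (0.39 log units; beyond the scatter). Both steps are modest and point towards weaker inhibition, whereas the exchange of aromatic substituents alone, a 1.3-fold lower number from compound 1 to compound 2 (0.11 log units; within the scatter), stays within the scatter. The entering group brings 2 hydrogen-bond donors and 1 hydrogen-bond acceptor where the 3-(trifluoromethyl)phenyl group has none, but no available measurement explains the loss.

The compounds shown do not separate the contribution of the chloro substituent from that of the added carbamoylamino unit, since both differ at once in these steps. Also open, on these data alone, is how this assay would read with a carboxylic acid or a primary amine on the phenyl ring, or with a longer chain on this nitrogen in place of the aryl group.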